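The source may report more compounds than this note shows. Statements on the series, on what has been measured and on what is new or still open speak of the compounds shown alone.

For the measured compounds named here, compound 3 `Cn1nc(-c2ccnc(Nc3cccc(O)c3)n2)c2ccccc21` gives the lowest number of the three compounds measured so far: in a functional assay on HCT-116 cells (Homo sapiens) for antiproliferative activity, read by MTT assay, with a stated time of 72 h (a higher number here means a weaker inhibitor of growth, a lower number a stronger inhibitor of growth), compound 3 gives 17200 nM, while compound 1 `c1ccc(Cn2c(Nc3ccccc3)nc3ncccc32)cc1` gives 64700 nM and compound 2 `Oc1ccc(Nc2nc3ncccc3n2Cc2ccccc2)cc1` gives 72600 nM, both of them beyond the scatter from compound 3. Compound 4 `Cn1nc(-c2ccnc(Nc3ccc(Cl)cc3)n2)c2ccccc21` differs from compound 3 by a single change, (4-chlorophenyl in place of 3-hydroxyphenyl on a nitrogen on an aromatic ring). Going by the values given here, the only measured step that touches a hydroxy group is a 1.1-fold higher number from compound 1 to compound 2 (0.05 log units; within the scatter), which lay within the scatter, and it was seen on the core of compound 1 rather than that of compound 3. Among the compounds with values here, no measured step shows a chlorine entering. The step from compound 3 to compound 4 is therefore expected to be small, a 1.1-fold lower number from compound 3 to compound 4 (0.06 log units; within the scatter), with no clear direction. Compound 4 is estimated at 15000 nM, within a range from 5000 nM to 50000 nM.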

Compound 4, concentration for 50% growth inhibition: 8730 nM
Beside the measured number, compound 4's estimate is 1.7-fold (0.24 log units) above it, and the stated range covers the measured number.
By their numbers in this assay, from the lowest: compounds 4 and 3 (each within the scatter of the next); then compounds 1 and 2 (each within the scatter of the next).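

Swapping (3-hydroxyphenyl)amino for (4-chlorophenyl)amino gives a 2.0-fold lower number from compound 3 to compound 4 (0.29 log units; within the scatter) in this assay on the shared core. For the compounds shown here, this is the first step at this place, and it shows that the number stays within the scatter even though the group goes from 1 hydrogen-bond donor and 1 acceptor to none of either. No measured evidence explains this result. Going by these compounds, the swap also alters the substituent and its ring position together, so their separate contributions remain open. On these data alone, whether an amine or a carboxylic acid on this phenyl ring would shift the number beyond the scatter also remains unknown.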